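A few compounds are considered here, and "the series" means these few. Any claim that something is new, unique, unknown or untested is made for them only; others in the source may bear on it.

Compound 1 `O=S(=O)(c1ccc(F)c(Cl)c1)c1cnc2c(F)cccc2c1-c1ccc(F)cc1`: 0.19 mL/min
Compound 2 `O=S(=O)(c1ccc(F)c(Cl)c1)c1cnc2c(F)cccc2c1-c1cccc(F)c1`: 1.23 mL/min
Compound 3 `COc1ccc(S(=O)(=O)c2cnc3cc(F)ccc3c2-c2cccc(F)c2)cc1`: 2.94 mL/min

All three were tested in an ADME assay on microsomes from liver (Homo sapiens) for metabolic stability, tested at 2.5 uM; a higher number here means faster removal of the compound, a lower number slower removal. Compound 1 and compound 2 share one core and differ in a single group: 4-fluorophenyl in place of 3-fluorophenyl on an aromatic carbon. That change gave a 6.5-fold lower number from compound 2 to compound 1 (0.81 log units; beyond the scatter). Compound 3 is built on a different core, and the difference between the two cores is not broken down here; in this assay compound 3 gives 2.94 mL/min, the highest of the three numbers.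

Compound 4 `COc1ccc(S(=O)(=O)c2cnc3cc(F)ccc3c2-c2ccc(F)cc2)cc1` has not yet been measured. It is made from compound 3 by the change (4-fluorophenyl in place of 3-fluorophenyl on an aromatic carbon). The place of the change reads the same word for word in both pairs, so it is the same change that was seen in going from compound 2 to compound 1. Its effect is known from one measured pair only, on another core, so how fully it carries over is uncertain. Going by the values given here, the expected step is a 4.9-fold lower number from compound 3 to compound 4 (0.69 log units; beyond the scatter), in the same direction but judged a little smaller, resting on the single measured step of a 6.5-fold lower number from compound 2 to compound 1 (0.81 log units; beyond the scatter) and on the starting value of compound 3, 2.94 mL/min. On that basis compound 4 is estimated at 0.6 mL/min in this assay, with an expected range from 0.25 mL/min to 1.5 mL/min.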

Compound 4, intrinsic clearance in a liver preparation (reported as CLH), per the amount of preparation that the assay uses: 1.71 mL/min
The estimate for compound 4 lay 2.9-fold (0.45 log units) below the measured number; the measured number lies above the stated range.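

On the core of compound 3, putting 4-fluorophenyl in place of 3-fluorophenyl gave a 1.7-fold lower number from compound 3 to compound 4 (0.24 log units; within the scatter) in this assay, a step that cannot be told apart from the differences expected between repeat measurements, so the clear effect seen on the core of compound 1 did not carry over at full size. The gap between the two steps is itself larger than the scatter, which shows that, for this pair of cores, the size of the effect depends on the core it is made on: the same change on two cores in this assay, a 6.5-fold lower number (0.81 log units; beyond the scatter) from compound 2 to compound 1 and a 1.7-fold lower number (0.24 log units; within the scatter) from compound 3 to compound 4, 3.8-fold (0.58 log units) apart, beyond the scatter of two such steps. Going by these compounds alone, this rests on only two matched pairs, so it does not show which part of the cores makes the difference, whether the change has any real effect on the core of compound 3, or how a third core would respond.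

All the compounds shown carry a fluorophenyl group at this place, so it remains open how a plain phenyl, or a phenyl bearing a nitrile or an amine, would behave in this assay. Also open, on these data alone, is whether the effect of moving the fluorine would change if the methoxy group of compound 3 gave way to a chlorine atom or a carboxylic acid.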